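Pentafluorosulfanyl to trifluoromethyl swap on the thioether and ether arms

The source may report more compounds than this note shows. Statements on the series, on what has been measured and on what is new or still open speak of the compounds shown alone.

Measured so far:
compound 1 `CC(O)(CSc1cccc(S(F)(F)(F)(F)F)c1)C(=O)Nc1cccc(S(F)(F)(F)(F)F)c1`: 30300 nM
compound 2 `CC(O)(CSc1cccc(C(F)(F)F)c1)C(=O)Nc1cccc(S(F)(F)(F)(F)F)c1`: 19100 nM
compound 3 `CC(O)(COc1ccc(S(F)(F)(F)(F)F)cc1)C(=O)Nc1cccc(S(F)(F)(F)(F)F)c1`: 12800 nM

All three were tested in a functional assay on DU-145 cells (Homo sapiens) for antiproliferative activity, read by propidium iodide staining, with a stated time of 96 h; on this read-out lower numbers stand for stronger inhibition and higher numbers for weaker inhibition. Compound 1 gives 30300 nM, compound 2 gives 19100 nM and compound 3 gives 12800 nM. Compound 3 has the lowest of the three numbers; its gap to compound 2 lies within the scatter, its gap to compound 1 beyond it.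

One change is seen once in measured pairs and once in an open pair. From compound 1 to compound 2 it is a group of 4 heavy atoms (1 carbon, 3 fluorine; no ring) in place of a group of 6 heavy atoms (5 fluorine, 1 sulfur; no ring), on an aromatic carbon and it gave a 1.6-fold lower number from compound 1 to compound 2 (0.20 log units; within the scatter). The core of compound 3 differs from that of compound 1 in more than one place, so the difference between the two cores is not broken down here.

Compound 4 `CC(O)(COc1ccc(C(F)(F)F)cc1)C(=O)Nc1cccc(S(F)(F)(F)(F)F)c1` is still to be measured in this assay. It arises from compound 3 by a group of 4 heavy atoms (1 carbon, 3 fluorine; no ring) in place of a group of 6 heavy atoms (5 fluorine, 1 sulfur; no ring), on an aromatic carbon. This is the same kind of change as from compound 1 to compound 2, not the same: there the group sits meta to a large group, here para to a large group. Among the measured compounds shown here, with only one earlier instance, and that within the scatter, a step of similar size is expected, because compound 3 starts at 12800 nM and the earlier pair showed a 1.6-fold lower number from compound 1 to compound 2 (0.20 log units; within the scatter). The expected step is a 1.5-fold lower number from compound 3 to compound 4 (0.18 log units; within the scatter). Compound 4 is therefore estimated at 8500 nM, with a range from 3500 nM to 20000 nM.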

Compound 4, half-maximal inhibitory concentration: 13600 nM
Estimate against measurement, compound 4: 1.6-fold (0.20 log units) below; the measured number falls inside the stated range.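

In this assay, the exchange of pentafluorosulfanyl for trifluoromethyl on the ether arm gave a 1.1-fold higher number from compound 3 to compound 4 (0.03 log units; within the scatter). Set beside the same exchange on the thioether arm, the new step shows no difference that exceeds the scatter: the same change on two cores in this assay, a 1.6-fold lower number (0.20 log units; within the scatter) from compound 1 to compound 2 and a 1.1-fold higher number (0.03 log units; within the scatter) from compound 3 to compound 4, 1.7-fold (0.23 log units) apart, within the scatter of two such steps So on these two cores the exchange can be carried across without a measurable change in the read-out, but two pairs, both within the scatter, do not show that the two groups are interchangeable elsewhere in the series, and they cannot separate the contribution of the linking atom from that of the group's position, as the two cores differ in more than one place.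

The compounds shown leave open whether the same holds for other replacements at this aromatic carbon, such as a nitrile, an amine or a carboxylic acid, or for a longer chain in place of the ether or thioether arm. They also leave open what happens when the pentafluorosulfanyl group on the amide side, common to all four compounds, is replaced, or when the hydroxyl group is removed.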